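Bromo for 2-cyanoethyl on the shared core

A few compounds are considered here, and "the series" means these few. Any claim that something is new, unique, unknown or untested is made for them only; others in the source may bear on it.

Measured so far in a functional assay on the whole organism with Rattus norvegicus as the target, with a stated time of 4 h, at a dose of 40 mg/kg by the intraperitoneal route; on this read-out higher numbers stand for more inhibition at the one dose given (going by the name of the read-out) and lower numbers for less inhibition:
compound 1 `CC(=O)c1c(C)nc2c(OCc3ccccc3)cccn12`: 57%
compound 2 `Cc1nc2c(OCc3ccccc3)cccn2c1C#N`: 25%
compound 3 `Cc1nc2c(OCc3ccccc3)cccn2c1CCC#N`: 40%

Compound 3 stands second highest of the three, with a number 17 percentage points lower from compound 1 to compound 3 (beyond the scatter) and a number 15 percentage points higher from compound 2 to compound 3 (beyond the scatter). Compound 4 `Cc1nc2c(OCc3ccccc3)cccn2c1Br` differs from compound 3 by bromo in place of 2-cyanoethyl on an aromatic carbon. For the measured compounds named here, no measured step introduces bromo, so the nearest guide is the pair of steps at this same carbon: a number 32 percentage points lower from compound 1 to compound 2 (beyond the scatter) and a number 15 percentage points higher from compound 2 to compound 3 (beyond the scatter), which show that the small cyano group sits below both larger groups. A single-atom bromo is expected to land nearer compound 2 than compound 3, so a modest drop is estimated, a number 10 percentage points lower from compound 3 to compound 4 (within the scatter). Compound 4 is therefore estimated at 30%, with a range from 12% to 48% in this assay.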

Compound 4, a percentage reported as inhibition, in the whole organism at one dose (the size of the read-out at that dose, not a potency): 26%
Estimate against measurement, compound 4: 4 percentage points above; measured number inside the range.
By their numbers in this assay, from the lowest: compounds 2 and 4 (each within the scatter of the next); then compound 3; then compound 1.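

At this aromatic carbon in this assay, bromo gives a number 14 percentage points lower from compound 3 to compound 4 (beyond the scatter) and a number 31 percentage points lower from compound 1 to compound 4 (beyond the scatter), whereas the change from cyano gives a number 1 percentage points higher from compound 2 to compound 4 (within the scatter), so bromo and cyano are not separated. Acetyl and 2-cyanoethyl thus both stand apart from two different groups, not from cyano alone as the earlier compounds showed.

Going by these compounds, whether an amine or a carboxylic acid at this carbon would match compound 1 stays open, as does how a longer chain ending in a nitrile would compare with compound 3. No measured evidence bears on why these groups divide this way.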